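The source may hold more compounds than are shown below. What is called first, only, known or untested is meant among the compounds shown, and "the series" means these compounds.

Compound 1 `CCCC(=O)c1ccc(OCCCCOc2cccc(C(=O)O)c2C)c(C)c1O` and compound 2 `Cc1c(OCCCCOc2ccc(C(=O)C(C)C)c(O)c2C)cccc1C(=O)O` share one core and differ only in the chain on the carbonyl carbon. Among the measured compounds shown here, in an assay on HEK293 cells for positive allosteric modulation of metabotropic glutamate receptor 2 (Rattus norvegicus), read by thallium flux, with a stated time of 2.5 min (a higher number here means a larger maximal response, a lower number a smaller maximal response), compound 1 reaches 82.4%, while compound 2 reaches 66.9%, the lower of the two numbers known so far; the change between them is a number 15.5 percentage points lower from compound 1 to compound 2 (beyond the scatter), a drop beyond the usual scatter. Compound 3 `CCC(=O)c1ccc(OCCCCOc2cccc(C(=O)O)c2C)c(C)c1O` belongs to the same family. From compound 2 it differs by hydrogen in place of methyl on a saturated chain carbon bound to a carbonyl carbon and a saturated chain carbon. Read one bond further out, this turns isopropyl into ethyl, so the branched chain of compound 2 becomes a straight one again, as in compound 1, only shorter. For the measured compounds named here, the single measured step that bears on this, a number 15.5 percentage points lower from compound 1 to compound 2 (beyond the scatter), showed the branched chain giving the smaller response; removing the branch is expected to recover at least part of that loss, though the shorter chain has no measured precedent here. The step is therefore estimated at a number 11.1 percentage points higher from compound 2 to compound 3 (beyond the scatter), an increase. Compound 3 is expected to reach about 78%, within a range from 62% to 92%.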

Compound 3, largest response reached (reported as percent of maximum), in percent of the reference or control that the assay uses: 71.3%
Compound 3: middle estimate off by 6.7 percentage points, on the high side; low and high end bracket the measured number.
By their numbers in this assay, from the lowest: compounds 2 and 3 (each within the scatter of the next); then compound 1.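

In this assay, removing the branch does not by itself bring the response back: a number 4.4 percentage points higher from compound 2 to compound 3 (within the scatter), so the isopropyl and ethyl chains on the carbonyl carbon cannot be told apart here. Shortening the straight chain also has a measured cost, a number 11.1 percentage points lower from compound 1 to compound 3 (beyond the scatter), which shows that the earlier loss is not tied to branching alone, since a straight chain can give a smaller response too; among these three compounds, only the propyl chain of compound 1 stands clear of the other two. Nothing given here explains how the chain on the carbonyl carbon affects the response.

The compounds shown leave open whether a longer straight chain, such as butyl or pentyl, would give a larger response than propyl or a smaller one, and so whether propyl marks a peak or just one point on a rising line. They also leave open how a cyclopropyl ring or a single methyl group on the carbonyl carbon would compare with these chains.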